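Dropping the Methylpiperazine from a Weak Amidine

The source may report more compounds than this note shows. Statements on the series, on what has been measured and on what is new or still open speak of the compounds shown alone.

Compound 1 `COc1ccc(Cn2cc3cc(C(=N)Nc4cccc(C(F)(F)F)c4)ncc3n2)cc1` — 15500 nM
Compound 2 `CN1CCN(c2ccc(NC(=N)c3cc4cn(C)nc4cn3)cc2)CC1` — 20500 nM

Two amidines have been tested in a functional assay on MDA-MB-231 cells (Homo sapiens) for cytotoxicity, read by MTT assay, with a stated time of 72 h; a lower number here means a stronger inhibitor, a higher number a weaker inhibitor. Compound 2 gives the higher of the two numbers, but compound 1 sits only slightly lower, and that gap lies within the scatter; both are weak. Compound 3 `Cn1cc2cc(C(=N)Nc3ccccc3)ncc2n1` differs from compound 2 by hydrogen in place of 4-methylpiperazin-1-yl on an aromatic carbon. Among the measured compounds shown here, no measured pair shows what this change does, so the size of the step is unknown. Because compound 2 already gives 20500 nM, the expected step is a 1.5-fold higher number from compound 2 to compound 3 (0.17 log units; within the scatter), at most a small drift toward a higher number. Compound 3 is therefore estimated at 30000 nM, with a range from 9000 nM to 100000 nM.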

Compound 3, half-maximal inhibitory concentration: > 50000 nM
Compound 3 gave a limit, no number; the forecaster's own chance of this, stated with the estimate: 30%; at least 1.6-fold (0.22 log units) between middle value and limit.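

In this assay, compound 3 reads only as a limit, not a number: the limit of > 50000 nM in this assay, at which 1 of the 3 values shown sits.

Hydrogen in place of 4-methylpiperazin-1-yl on this aromatic carbon still gives an at least 2.4-fold higher number from compound 2 to compound 3 (0.38 log units; beyond the scatter), so the first measured step at this position shows that the group's loss is not neutral, even from a weak starting point.

On these data alone, how far the true value of compound 3 lies past its limit remains open, and with it the full size of the step. Also open, as far as these compounds go, is whether a morpholine or a dimethylamino group at this carbon would keep the activity of compound 2.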